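The compounds below may be only part of what the source reports. "The series", "measured", "known", "first", "only" and "open" are said of these compounds alone.

Compound 3 `CC(C)(C)c1ccc(SCc2ccc(C(=O)Nc3ccccc3N)cc2)cc1` carries a tert-butylphenyl on its sulfur and, in a functional assay on SMMC-7721 cells (Homo sapiens) for inhibition, read by CCK-8 assay, with a stated time of 72 h, tested at 8 uM (a lower number here means less inhibition of growth, a higher number more inhibition of growth at the concentration tested), compound 3 gives 46.1%. Among the three compounds measured so far this places compound 3 at the upper end: compound 1 `COc1ccc(SCc2ccc(/C=C/C(=O)Nc3ccccc3N)cc2)cc1OC` gives 44.6%, a value that cannot be separated from that of compound 3 within the scatter, while compound 2 `Nc1ccccc1NC(=O)/C=C/c1ccc(CSc2ccc(Cl)cc2)cc1` gives 16.5%, well below both.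

Compound 4 `Nc1ccccc1NC(=O)c1ccc(CSc2ccc(Cl)cc2)cc1` has not yet been measured. The change from compound 3 to compound 4 is chloro in place of tert-butyl on an aromatic carbon. Within the data shown here, one measured step bears on this: a number 28.1 percentage points lower from compound 1 to compound 2 (beyond the scatter), where a chloro-bearing ring likewise took the place of a more substituted ring on the sulfur, in the pair that carries a vinyl linker rather than the direct amide of compounds 3 and 4. A move toward the chloro ring thus came with a modest loss of growth inhibition in that pair, and a step of similar size in the same direction is expected here, a number 26.1 percentage points lower from compound 3 to compound 4 (beyond the scatter). Compound 4 is therefore estimated at 20%, within a range of 8% to 35%.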

Compound 4, percent growth inhibition at one concentration: 16.5%
Estimate against measurement, compound 4: 3.5 percentage points above; the measured number falls inside the stated range.
By their numbers in this assay, from the lowest: compounds 2 and 4 (each within the scatter of the next); then compounds 1 and 3 (each within the scatter of the next).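

With a direct amide in place of the vinyl linker, the chloro compound again falls well short of its partner on the sulfur side, with a number 29.6 percentage points lower from compound 3 to compound 4 (beyond the scatter) in this assay for a single swap of tert-butyl for chloro on the aromatic carbon. The earlier step had set chloro against a 3,4-dimethoxyphenyl ring in the vinyl pair, so the loss now appears with a different group leaving and a different linker, and compound 2 at 16.5% and compound 4 at 16.5% cannot be separated within the scatter. Nothing shown here explains the step.

The compounds shown leave open how a methyl group, an amine or a carboxylic acid on this same aromatic carbon would read. They also leave open whether the step follows the arrival of chloro or the departure of tert-butyl, and a ring with hydrogen at this carbon would bear on that.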